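From 3-methylbut-2-en-1-yl to 2-oxopropyl on the shared core

The source may hold more compounds than are shown below. What is called first, only, known or untested is meant among the compounds shown, and "the series" means these compounds.

In a functional assay (trachea) with Cavia porcellus as the target (on this read-out higher numbers stand for weaker inhibition and lower numbers for stronger inhibition), compound 1 (`Cn1nc(-c2cccnc2)c2ccccc2c1=O`) gives 11500 nM, compound 2 (`C=CCn1nc(-c2cccnc2)c2ccccc2c1=O`) gives 2140 nM and compound 3 (`CC(C)=CCn1nc(-c2cccnc2)c2ccccc2c1=O`) gives 1380 nM. Compound 3 sits with compound 2 at the low end of these numbers, with a 1.6-fold lower number from compound 2 to compound 3 (0.19 log units; within the scatter). Both lie clearly under compound 1, with a 5.4-fold lower number from compound 1 to compound 2 (0.73 log units; beyond the scatter) and an 8.3-fold lower number from compound 1 to compound 3 (0.92 log units; beyond the scatter).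

Compound 4 (`CC(=O)Cn1nc(-c2cccnc2)c2ccccc2c1=O`) carries acetyl in place of 2-methylprop-1-en-1-yl on a saturated chain carbon bound to an aromatic nitrogen.

For the measured compounds named here, no measured step introduces acetyl, so the evidence is indirect. The gain seen with an 8.3-fold lower number from compound 1 to compound 3 (0.92 log units; beyond the scatter) suggests that some of the benefit of a group at this place may survive, yet no measured chain contains oxygen. A modest move toward a higher number is therefore expected in this assay, and it may not clear the scatter. The expected step is a 2.5-fold higher number from compound 3 to compound 4 (0.40 log units; beyond the scatter). For compound 4 the estimated value is 3500 nM, with an expected range of 1200 nM to 10000 nM.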

Compound 4, half-maximal inhibitory concentration: 40700 nM
For compound 4 the middle estimate is 12-fold (1.07 log units) below the measured one; measured number above the stated range.
By their numbers in this assay, from the lowest: compounds 3 and 2 (each within the scatter of the next); then compound 1; then compound 4.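

In this assay a group at this place does not only lower the number: acetyl in place of 2-methylprop-1-en-1-yl gives a 29-fold higher number from compound 3 to compound 4 (1.47 log units; beyond the scatter) and acetyl in place of vinyl gives a 19-fold higher number from compound 2 to compound 4 (1.28 log units; beyond the scatter) so a gain seen with the two alkene-bearing chains does not carry over to the chain with a carbonyl. Unlike compounds 2 and 3, which both lie under compound 1, the 2-oxopropyl chain reverses the direction, with a 3.5-fold higher number from compound 1 to compound 4 (0.55 log units; beyond the scatter) as its step from the same starting point. No supporting data bear on why this change acts as it does.

Open, going by these compounds, is whether the rise belongs to the carbonyl alone or would also appear with a 2-hydroxypropyl chain on a saturated chain carbon bound to an aromatic nitrogen. Also open, on these data alone, is how a plain butyl chain, an amine or a carboxylic acid would read at this place.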